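A 3-aminopiperidin-1-yl in place of piperazin-1-yl

This account rests on a few compounds, and the source may have more. Where it says the series, first, only, none or still open, it means among the compounds named here.

Only two reference points exist in an ADME assay on microsomes from intestine (Rattus norvegicus) for metabolic stability, with NADPH named in the record, with a stated time of 60 min, in the absence of a further agent (on this read-out higher numbers stand for a more stable compound and lower numbers for a less stable compound), for this series. In that read-out, compound 1 (`Cc1cncc(-c2ccc3cnn(-c4cccc(N5CCCNCC5)n4)c3c2)n1`) gives 91% as its reading. Compound 2 (`c1cncc(-c2cc3c(-c4cccc(N5CCNCC5)n4)n[nH]c3cn2)c1`) has no single number, and compound 2 is reported only as "stable" (no number reported) in words, so it cannot be placed exactly beside compound 1.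

Compound 3 (`N[C@H]1CCCN(c2cccc(-c3n[nH]c4cnc(-c5cccnc5)cc34)n2)C1`) has yet to be measured. It carries 3-aminopiperidin-1-yl in place of piperazin-1-yl on an aromatic carbon of a six-membered aromatic ring with 1 nitrogen, next to the ring nitrogen, and the change counts as 3-aminopiperidin-1-yl in place of piperazin-1-yl on an aromatic carbon in full.

For the measured compounds named here, no measured pair shows what this exchange does in this assay on its own. A step no larger than the usual scatter is therefore expected, with no firm direction. That expectation rests on compound 1 at 91% and on compound 2 at "stable" (no number reported) as its reported result, and it remains weak support. For compound 3 the estimated value is 86% with 65% to 100% as the expected range.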

Compound 3, percent of the compound remaining: 93%
Compound 3: middle estimate off by 7 percentage points, on the low side; measured number inside the range.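

In this assay, for the compounds shown here, compound 3 gives 93% while compound 2 is recorded as "stable" (no number reported) without a figure, so no step between compound 2 and compound 3 can be read. The compounds shown leave open what 3-aminopiperidin-1-yl in place of piperazin-1-yl does on its own in this read-out. Nothing available bears on the result.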